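Adding a Methyl to an Amide Nitrogen, Twice Over

The source may report more compounds than this note shows. Statements on the series, on what has been measured and on what is new or still open speak of the compounds shown alone.

Three compounds have been measured in a functional assay on CCRF-CEM cells (Homo sapiens) for inhibition, with a stated time of 72 h; a lower number here means a stronger inhibitor, a higher number a weaker inhibitor:

Compound 1, `COC(=O)C[C@H](NC(=O)OC(C)(C)C)C(=O)NC1(C(=O)NCc2ccccc2)CCN(Cc2ccccc2)CC1`: 25000 nM
Compound 2, `COC(=O)C[C@H](NC(=O)OC(C)(C)C)C(=O)N(C)C1(C(=O)NCc2ccccc2)CCN(Cc2ccccc2)CC1`: 20000 nM
Compound 3, `CNC(=O)C[C@H](NC(=O)OC(C)(C)C)C(=O)N(Cc1ccccc1)C1(C(=O)NCc2ccccc2)CCN(Cc2ccccc2)CC1`: 63000 nM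

Compound 2 differs from compound 1 by methyl in place of hydrogen on an amide-type nitrogen, and that change gave a 1.3-fold lower number from compound 1 to compound 2 (0.10 log units; within the scatter). Compound 3 has a different core, and the difference between the two cores is not broken down here; its number is the highest of the three.

Compound 4, `CN(C)C(=O)C[C@H](NC(=O)OC(C)(C)C)C(=O)N(Cc1ccccc1)C1(C(=O)NCc2ccccc2)CCN(Cc2ccccc2)CC1`, has not yet been measured. It differs from compound 3 by methyl in place of hydrogen on an amide-type nitrogen. Among the measured compounds shown here, this is the same kind of change as the one from compound 1 to compound 2, but not the same: in compound 1 the nitrogen's other neighbours are a carbonyl carbon and a saturated ring carbon, whereas in compound 3 they are a carbonyl carbon and a saturated chain carbon.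

Because a 1.3-fold lower number from compound 1 to compound 2 (0.10 log units; within the scatter) stayed within the scatter, only a small move is expected here too. Compound 4 is expected to show a 1.1-fold lower number from compound 3 to compound 4 (0.06 log units; within the scatter) in this assay. Compound 4 is thus estimated at 55000 nM, plausibly between 25000 nM and 120000 nM.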

Compound 4, half-maximal inhibitory concentration: 59000 nM
Compound 4: the middle estimate sits 1.1-fold (0.03 log units) below what was measured; measured number inside the range.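

Placing a methyl on the amide-type nitrogen of compound 3 gives a 1.1-fold lower number from compound 3 to compound 4 (0.03 log units; within the scatter) in this assay, so this step does not separate the two compounds. Set beside the earlier step, the change leaves the number within the scatter on both cores, and the two steps do not differ from each other: the same change on two cores in this assay, a 1.3-fold lower number (0.10 log units; within the scatter) from compound 1 to compound 2 and a 1.1-fold lower number (0.03 log units; within the scatter) from compound 3 to compound 4, 1.2-fold (0.07 log units) apart, within the scatter of two such steps This shows that, in these two pairs, the result carried over from one core to the other, even though the nitrogen's saturated neighbour is a ring carbon in one pair and a chain carbon in the other, but two pairs make no general rule and do not show that the change would stay this small on another core.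

The compounds shown leave open whether an ethyl or a longer chain on that nitrogen would move the number beyond the scatter. They also leave open what a carboxylic acid in place of the dimethylcarbamoyl group would do.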